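Shortening the ether side group of compound 2

A few compounds are considered here, and "the series" means these few. Any claim that something is new, unique, unknown or untested is made for them only; others in the source may bear on it.

In a functional assay on PC-12 cells (Rattus norvegicus) for inhibition, read by sulforhodamine B assay (a higher number here means a weaker inhibitor, a lower number a stronger inhibitor), compound 1 (`Cc1c(C)c2c(c(C)c1O)CCC(C)(COc1ccc(/C=C3/SC(=O)NC3=O)cc1)O2`) gives 5000 nM as its half-maximal inhibitory concentration, and compound 3 (`O=C1NC(=O)/C(=C/c2ccc(OCC3CC3)cc2)S1`) gives 23000 nM on the same read-out. Compound 2 (`O=C1NC(=O)C(Cc2ccc(OCC3CCCCO3)cc2)S1`) gives > 100000 nM and this is a limit of the assay, not a number. Its place in this small set is the limit of > 100000 nM in this assay, at which 1 of the 3 values shown sits, and no exact value exists for it.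

Compound 4 (`CC(C)COc1ccc(CC2SC(=O)NC2=O)cc1`) has not yet been measured. It differs from compound 2 in one place, isopropyl in place of oxan-2-yl on a saturated chain carbon bound to an oxygen on an aromatic ring and the swap puts isopropyl in place of oxan-2-yl on a saturated chain carbon bound to an oxygen on an aromatic ring.

For the measured compounds named here, no measured pair shows this swap on its own, and compound 1 and compound 3 each differ from compound 4 in more than this one place. Compound 3 at 23000 nM is still the closest guide. A modest step towards stronger inhibition in this assay is therefore expected, possibly none beyond the scatter, with compound 4 remaining a weak inhibitor. The expected change is an at least 1.4-fold lower number from compound 2 to compound 4 (0.15 log units; that floor lies within the scatter) and it is rough since it starts from a limit. For compound 4 the estimated value is 70000 nM with an expected range from 25000 nM to 150000 nM on this read-out.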

Compound 4, half-maximal inhibitory concentration: 25000 nM
Compound 4: middle estimate off by 2.8-fold (0.45 log units), on the high side, and the stated range covers the measured number.
By their numbers in this assay, from the lowest: compound 1; then compounds 3 and 4 (each within the scatter of the next). At a limit, above all of these: compound 2.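

In this assay, putting isopropyl in place of oxan-2-yl on a saturated chain carbon bound to an oxygen on an aromatic ring gives an at least 4.0-fold lower number from compound 2 to compound 4 (0.60 log units; beyond the scatter). For the compounds shown here, this is the only pair here that differs in one place, and it shows that the group at this position matters in this assay: the six-membered ring with its oxygen is not needed for a measurable value, and compound 4, with the smaller isopropyl group, gives 25000 nM. The step sets only a minimum size, and its full size stays unknown because compound 2 is a limit of the assay and not a number: the limit of > 100000 nM in this assay, at which 1 of the 4 values shown sits.

This one pair cannot separate the loss of the ring from the loss of its oxygen, and a cyclohexyl group in place of oxan-2-yl would be needed to tell those two apart. Also open, on these data alone, is how a longer chain or an amine at this same place would read on the same core, so no trend in group size can be drawn from one step.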